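The compounds below may be only part of what the source reports. "The series", "measured", "known", "first", "only" and "open" are said of these compounds alone.

Measured compounds:
- compound 1, `COc1cc2cc(Oc3ccc(NC(=O)Nc4ccc(C)cc4)cc3)c(C)nc2cc1OC`, in a functional assay on HCT-116 cells (Homo sapiens) for inhibition, read by sulforhodamine B assay, with a stated time of 48 h, tested at 10 uM (on this read-out lower numbers stand for a stronger effect and higher numbers for a weaker effect at the one concentration tested), compound 1 gives 107%
- compound 2, `COc1cc2cc(Oc3ccc(NC(=O)Nc4cccc(C(F)(F)F)c4)cc3)c(C)nc2cc1OC`, in this assay compound 2 gives 6.71%

For the measured compounds named here, compound 2 holds the lowest of the two numbers in this assay; its only neighbour is compound 1, and that gap is well beyond the scatter. Going by the values given here, the single measured step, a number 100.3 percentage points lower from compound 1 to compound 2 (beyond the scatter), is the swap of 3-(trifluoromethyl)phenyl for 4-methylphenyl on the amide-type nitrogen, and it is large.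

Compound 3, `COc1cc2cc(Oc3ccc(NC(=O)Nc4ccc(Cl)c(C(F)(F)F)c4)cc3)c(C)nc2cc1OC`, is not yet measured. It differs from compound 2 by chloro in place of hydrogen on an aromatic carbon, giving a 4-chloro-3-(trifluoromethyl)phenyl in place of the 3-(trifluoromethyl)phenyl.

Among the compounds with values here, no measured step bears on a chloro in this place; the one step on record concerns the whole aryl group and says only that the 3-(trifluoromethyl)phenyl already sits at the strong end of this assay. With compound 2 already so low, there is little room for a further fall, and a small added chloro gives no grounds to expect a loss. The step from compound 2 to compound 3 is therefore expected to be a number 1.7 percentage points lower from compound 2 to compound 3 (within the scatter), within the scatter. For compound 3 in this assay the estimate is 5%, between 0% and 20%.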

Compound 3, a percentage reported as activity, at one concentration (the size of the read-out at that concentration, not a potency): -87.3%
Beside the measured number, compound 3's estimate is 92.3 percentage points above it, and the stated range ends above it.
By their numbers in this assay, from the lowest: compound 3; then compound 2; then compound 1.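

In this assay the place on the aromatic ring ortho to a trifluoromethyl group and para to a large group proves highly sensitive: chloro in place of hydrogen gives a number 94 percentage points lower from compound 2 to compound 3 (beyond the scatter) and so changes the result far more than the low number of compound 2 suggested. That low number was therefore not the end of the scale, since compound 3 gives -87.3% and moves the read-out to a negative number. Across the whole aryl group, 4-chloro-3-(trifluoromethyl)phenyl in place of 4-methylphenyl gives a number 194.3 percentage points lower from compound 1 to compound 3 (beyond the scatter) and spans the full range seen in the three compounds.

Still open, from the compounds shown here alone, is whether this step is particular to chloro or would also appear with fluoro, methoxy, nitrile or an amine in the same place, and whether chloro has a similar effect without the neighbouring trifluoromethyl group. No evidence at hand bears on the origin of this step.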